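A few compounds are considered here, and "the series" means these few. Any claim that something is new, unique, unknown or untested is made for them only; others in the source may bear on it.

The three compounds share one core and differ only in the group on an aromatic carbon of a six-membered aromatic ring of carbon only, part of a fused system of two rings. Compound 1, `Cc1c(C(=O)Nc2ccc(Oc3ncnc4[nH]cc(-c5ccccc5)c34)c(F)c2)c(=O)c2cc(F)ccc2n1C`, carries a fluoro there. In an assay on isolated protein for inhibition of tyrosine-protein kinase receptor UFO (Homo sapiens), read by FRET and Z'-LYTE, with a stated time of 1.5 h (a higher number here means a weaker inhibitor, a lower number a stronger inhibitor), compound 1 gives > 10000 nM, which is a limit of the assay rather than a number. Compound 2, `C=C(C)c1ccc2c(c1)c(=O)c(C(=O)Nc1ccc(Oc3ncnc4[nH]cc(-c5ccccc5)c34)c(F)c1)c(C)n2C`, carries a 1-methylethenyl in that place. In this assay, among the compounds with values here, compound 2 gives 170 nM, the only full number among the values shown. Within the data shown here, the one measured step, an at least 58-fold lower number from compound 1 to compound 2 (1.76 log units; beyond the scatter), shows that the group in this place can shift the result strongly, though how far is bounded by the limit of > 10000 nM in this assay, at which 1 of the 2 values shown sits. Compound 3, `Cc1c(C(=O)Nc2ccc(Oc3ncnc4[nH]cc(-c5ccccc5)c34)c(F)c2)c(=O)c2cc(C3CCCC3)ccc2n1C`, makes the change (cyclopentyl in place of 1-methylethenyl on an aromatic carbon). Among the measured compounds shown here, no measured step covers an exchange between two carbon-only groups of this kind, so the single step bears only loosely on it. Compound 2 gives 170 nM with a carbon-only group in this place, and compound 3 keeps a carbon-only group there. The expected step of a 1.3-fold higher number from compound 2 to compound 3 (0.11 log units; within the scatter) for compound 3 is therefore estimated to lie within the scatter. Compound 3 is estimated at 220 nM, in a range from 60 nM to 900 nM.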

Compound 3, half-maximal inhibitory concentration: 200 nM
Compound 3: middle estimate off by 1.1-fold (0.04 log units), on the high side, and the stated range covers the measured number.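

In this assay, the exchange gives a 1.2-fold higher number from compound 2 to compound 3 (0.07 log units; within the scatter), so cyclopentyl, with its five-membered non-aromatic ring and 5 heavy atoms, cannot be told apart in this place from 1-methylethenyl, with its 3 heavy atoms and its double bond outside aromatic rings. The double bond is thus not required for a value of this order, and the large difference from the fluoro compound now holds for a second carbon-only group, with an at least 50-fold lower number from compound 1 to compound 3 (1.69 log units; beyond the scatter). Compound 1 gives > 10000 nM, which is a limit of the assay and not a number, so the true size of both steps from it remains bounded: the limit of > 10000 nM in this assay, at which 1 of the 3 values shown sits.

What the compounds shown leave open is whether the step from fluoro depends on the group being carbon-only or simply on its being larger than fluoro, since the two groups that read alike share both features. On these data alone, how a small methyl, a flat phenyl, or a group carrying nitrogen or oxygen, such as an amine or a methoxy, would read in this place also remains open.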